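This account rests on a few compounds, and the source may have more. Where it says the series, first, only, none or still open, it means among the compounds named here.

Measured compounds:
compound 1, `COc1cc2c(Oc3ccc(NC(=O)c4nn(-c5ccccc5)c(=O)cc4C)cc3F)ccnc2cc1OCCCN1CCN(C)CC1`, in a functional assay on HT-29 cells (Homo sapiens) for inhibition, read by MTT assay, with a stated time of 72 h (on this read-out lower numbers stand for stronger inhibition and higher numbers for weaker inhibition), compound 1 gives 270 nM;
compound 2, `COc1cc2c(Oc3ccc(NC(=O)c4nn(-c5ccccc5C(F)(F)F)c(=O)cc4C)cc3F)ccnc2cc1OCCCN1CCN(C)CC1`, in this assay compound 2 gives 170 nM;
compound 3, `COc1cc2c(Oc3ccc(NC(=O)c4nn(-c5ccccc5OC(F)(F)F)c(=O)cc4C)cc3F)ccnc2cc1OCCCN1CCC(C)CC1`, in this assay compound 3 gives 250 nM.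

Compound 3 sits with the second highest of the three numbers, and its gaps to compound 1 and to compound 2 are both within the scatter, so the three measured compounds cannot be told apart on this read-out. Compound 4, `COc1cc2c(Oc3ccc(NC(=O)c4nn(-c5ccccc5OC(F)(F)F)c(=O)cc4C)cc3F)ccnc2cc1OCCCN1CCN(C)CC1`, is not yet measured. Its difference from compound 3 is 4-methylpiperazin-1-yl in place of 4-methylpiperidin-1-yl on a saturated chain carbon, three bonds along the chain from an oxygen on an aromatic ring; the rest of the molecule is kept. Among the compounds with values here, the only measured step, a 1.6-fold lower number from compound 1 to compound 2 (0.20 log units; within the scatter), concerns a change at a different place, on an aromatic ring, and so says nothing about the amine at the end of the chain. Compounds 1 and 2 carry the 4-methylpiperazin-1-yl group that enters in compound 4, and their numbers lie within the scatter of compound 3. On this basis the step is expected to be a 1.1-fold lower number from compound 3 to compound 4 (0.06 log units; within the scatter), with no change beyond the scatter. Compound 4 is therefore estimated at 220 nM in this assay, with a range from 100 nM to 500 nM.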

Compound 4, half-maximal inhibitory concentration: 180 nM
Beside the measured number, compound 4's estimate is 1.2-fold (0.09 log units) above it, within the range that was stated.
By their numbers in this assay, from the lowest: compounds 2, 4, 3 and 1 (each within the scatter of the next).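

In this assay, within the data shown here, 4-methylpiperazin-1-yl in place of 4-methylpiperidin-1-yl on a saturated chain carbon, three bonds along the chain from an oxygen on an aromatic ring, gives a 1.4-fold lower number from compound 3 to compound 4 (0.14 log units; within the scatter); this is the first measured step at the amine end of the chain, and on this read-out the two rings cannot be told apart. Compound 4 also links the aromatic substituents while the 4-methylpiperazin-1-yl group stays fixed: trifluoromethoxy in place of trifluoromethyl gives a 1.1-fold higher number from compound 2 to compound 4 (0.02 log units; within the scatter), and trifluoromethoxy in place of hydrogen gives a 1.5-fold lower number from compound 1 to compound 4 (0.18 log units; within the scatter), so hydrogen, trifluoromethyl and trifluoromethoxy cannot be separated in this set either. No measurement shown bears on the reason for these results.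

Going by these compounds, the amine exchange has been read only in compounds carrying trifluoromethoxy, so it remains open whether it would give a similar step with hydrogen or trifluoromethyl on the aromatic ring. On these data alone, it also remains open whether a different group at the end of the chain, such as morpholin-4-yl or dimethylamino, or a shorter or longer chain, would move the number beyond the scatter.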